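This account rests on a few compounds, and the source may have more. Where it says the series, first, only, none or still open, it means among the compounds named here.

Measured in a functional assay on K562 cells (Homo sapiens) for antiproliferative activity, read by MTT assay, with a stated time of 72 h; a lower number here means a stronger inhibitor, a higher number a weaker inhibitor:
- Compound 1 `COc1cc(-c2ncnn2-c2cccc(F)c2)cc(OC)c1OC`: > 10000 nM, a limit.
- Compound 2 `COc1ccc(-c2ncnn2-c2cc(OC)c(OC)c(OC)c2)cc1`: 950 nM.
- Compound 3 `COc1cc(-c2ncnn2-c2ccc(N)cc2)cc(OC)c1OC`: > 10000 nM, a limit.

Within the data shown here, compound 2 is the only compound read as a number. The other two sit at the limit of > 10000 nM in this assay, at which 2 of the 3 values shown sit.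

Compound 4 `COc1cc(-n2ncnc2-c2ccc(Cl)c(Cl)c2)cc(OC)c1OC` differs from compound 2 by 3,4-dichlorophenyl in place of 4-methoxyphenyl on an aromatic carbon: 3,4-dichlorophenyl in place of 4-methoxyphenyl, on an aromatic carbon of a five-membered aromatic ring with 3 nitrogen.

Among the measured compounds shown here, the only step between measured compounds, a step that the two limits leave unreadable from compound 1 to compound 3, lies on an aromatic nitrogen and gives no size for this change. The expectation therefore rests on compound 2 at 950 nM alone, and it is loose. A moderate weakening in this assay is expected, as a 3.2-fold higher number from compound 2 to compound 4 (0.50 log units; beyond the scatter). Compound 4 is estimated at 3000 nM, with an expected range of 600 nM to 10000 nM.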

Compound 4, half-maximal inhibitory concentration: > 10000 nM
Compound 4 was reported as a limit; the forecaster's own chance of this, stated with the estimate: 35%; middle value at least 3.3-fold (0.52 log units) from the limit.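

Among these compounds, the first readable step lies on the aromatic carbon between two ring nitrogen atoms: 3,4-dichlorophenyl in place of 4-methoxyphenyl gives an at least 10-fold higher number from compound 2 to compound 4 (1.02 log units; beyond the scatter) in this assay. Compound 4 stands at > 10000 nM, which is a limit, so the step has a floor but no full size. Among the compounds shown here, the 4-methoxyphenyl of compound 2 therefore remains the only group at this carbon with a numerical reading.

The compounds shown do not separate the loss of the methoxy group from the entry of the two chlorines. On these data alone, whether a hydroxyl or an amine on this phenyl ring would give a numerical reading remains open.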